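The source may hold more compounds than are shown below. What is called first, only, known or untested is meant among the compounds shown, and "the series" means these compounds.

Measured so far:
compound 1, `COc1cc(OC)c2sc(-c3ccc(N/C=C\C(=O)c4cc(OC)c(OC)c(OC)c4)cc3)nc2c1`: 17800 nM
compound 2, `COc1cc(OC)c2sc(-c3ccc(N/C=C\C(=O)c4ccc(OC)c(O)c4)cc3)nc2c1`: 12100 nM
compound 3, `COc1cc(OC)c2sc(-c3ccc(N/C=C\C(=O)c4cc(OC)c(OC)c(OC)c4Br)cc3)nc2c1`: 10300 nM

All three were tested in a functional assay on HeLa cells (Homo sapiens) for antiproliferative activity, read by sulforhodamine B assay, with a stated time of 48 h; a lower number here means a stronger inhibitor, a higher number a weaker inhibitor. Among these three numbers compound 1 gives the highest one, yet the other two stay within the scatter of it: the step of a 1.5-fold lower number from compound 1 to compound 2 (0.17 log units; within the scatter) and the step of a 1.7-fold lower number from compound 1 to compound 3 (0.24 log units; within the scatter) are both too small to count as real changes. So far, altering the ring on the carbonyl carbon has left the potency essentially where it was.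

Compound 4, `COc1cc(OC)c2sc(-c3ccc(N/C=C\C(=O)c4cc(OC)c(OC)c([N+](=O)[O-])c4)cc3)nc2c1`, has not been measured yet. It differs from compound 1 in one place: nitro in place of methoxy on an aromatic carbon. Both measured steps alter the same aromatic ring on the carbonyl carbon and so bear on this change. The step of a 1.5-fold lower number from compound 1 to compound 2 (0.17 log units; within the scatter) exchanges the whole ring, the step of a 1.7-fold lower number from compound 1 to compound 3 (0.24 log units; within the scatter) puts bromo in place of hydrogen, and neither moved the number beyond the scatter. Nitro in place of methoxy on that ring is therefore expected to behave in the same way, giving no step beyond the scatter in this assay in either direction, with a slight lean toward a higher number. The estimate for compound 4 in this assay is 20000 nM, with a range from 8000 nM to 50000 nM. That corresponds to an expected step of a 1.1-fold higher number from compound 1 to compound 4 (0.05 log units; within the scatter).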

Compound 4, half-maximal inhibitory concentration: 19000 nM
The estimate for compound 4 lay 1.1-fold (0.02 log units) above the measured number; the range from low to high includes it.
By their numbers in this assay, from the lowest: compounds 3, 2, 1 and 4 (each within the scatter of the next).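

In this assay, for the compounds shown here, the earlier steps exchanged the whole ring or put bromo in place of hydrogen, whereas this one replaces a single methoxy group, on the carbon ortho to a methoxy group and meta to a large group, and it gives a 1.1-fold higher number from compound 1 to compound 4 (0.03 log units; within the scatter) as the result. The swap is not a small one on paper: methoxy, with 2 heavy atoms and 1 hydrogen-bond acceptor, gives way to nitro, with 3 heavy atoms, 2 hydrogen-bond acceptors and a double bond outside the aromatic ring, yet the number stays within the scatter, so keeping this methoxy group is not needed to hold the activity at this level. No measurement among the data offers an explanation for why the number holds steady.

Still open, as far as these compounds go, is whether an amine or a carboxylic acid on this same carbon would move the number beyond the scatter in either direction. From the compounds shown here alone, with only methoxy and nitro compared directly here, it also remains unknown whether any group at this position can make the compound clearly stronger or weaker.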